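The source may report more compounds than this note shows. Statements on the series, on what has been measured and on what is new or still open speak of the compounds shown alone.

Of the compounds shown here, three on a shared core have so far been measured in a functional assay on HeLa cells (Homo sapiens) for inhibition, read by sulforhodamine B assay; a lower number here means a stronger inhibitor, a higher number a weaker inhibitor. Compound 1 `CCc1ccc(NC2=CC(=O)c3nc4n(c3C2=O)[C@H]2OC[C@@H](O)[C@H]2OC4)cc1` gives 3990 nM. Compound 3 `COc1ccc(NC2=CC(=O)c3nc4n(c3C2=O)[C@H]2OC[C@@H](O)[C@H]2OC4)cc1` gives 4780 nM, the higher of the two numbers; its nearest neighbour is compound 1, and the step of a 1.2-fold higher number from compound 1 to compound 3 (0.08 log units; within the scatter) lies within the scatter. Compound 2 `O=C1C=C(NC2CCCC2)C(=O)c2c1nc1n2[C@H]2OC[C@@H](O)[C@H]2OC1` returns only a limit, > 16000 nM, sitting at the limit of > 16000 nM in this assay, at which 1 of the 3 values shown sits, rather than at a number. The step of an at least 3.3-fold lower number from compound 2 to compound 3 (0.52 log units; beyond the scatter) and the step of an at least 4.0-fold higher number from compound 1 to compound 2 (0.60 log units; beyond the scatter) both show that cyclopentyl on the amine nitrogen gives a higher number than either aromatic group.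

Compound 4 `O=C1C=C(Nc2cccc(Cl)c2)C(=O)c2c1nc1n2[C@H]2OC[C@@H](O)[C@H]2OC1` has not yet been measured. It differs from compound 3 in one place: 3-chlorophenyl in place of 4-methoxyphenyl on an amine nitrogen. The measured step that bears on it is the one between the two aromatic compounds, a 1.2-fold higher number from compound 1 to compound 3 (0.08 log units; within the scatter), where exchanging one substituent on the aromatic ring for another left the number within the scatter. The change to compound 4 likewise keeps an aromatic group on the amine nitrogen, so the expected step of a 1.2-fold lower number from compound 3 to compound 4 (0.08 log units; within the scatter) is small and could fall in either direction. Compound 4 is therefore estimated at 4000 nM, with a range from 1500 nM to 11000 nM.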

Compound 4, half-maximal inhibitory concentration: 6040 nM
Beside the measured number, compound 4's estimate is 1.5-fold (0.18 log units) below it, and the stated range covers the measured number.
By their numbers in this assay, from the lowest: compounds 1, 3 and 4 (each within the scatter of the next). At a limit, above all of these: compound 2.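

In this assay, 3-chlorophenyl on the amine nitrogen stands level with both earlier aromatic groups: the step of a 1.3-fold higher number from compound 3 to compound 4 (0.10 log units; within the scatter) and the step of a 1.5-fold higher number from compound 1 to compound 4 (0.18 log units; within the scatter) both lie within the scatter, so the tolerance first seen between 4-ethylphenyl and 4-methoxyphenyl now also covers a chlorine-bearing ring with a differently numbered substituent. Among these compounds, the step of an at least 2.6-fold lower number from compound 2 to compound 4 (0.42 log units; beyond the scatter) shows that the separation from cyclopentyl holds for this third aromatic group too, and no compound with a substituted phenyl on this nitrogen goes against it. That separation is a bound and not an exact size, as compound 2 has a limit rather than a number: the limit of > 16000 nM in this assay, at which 1 of the 4 values shown sits.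

The compounds shown leave open whether unsubstituted phenyl, 4-chlorophenyl, or a phenyl ring carrying an amine or a carboxylic acid would stay in this same range. Also open, on these data alone, is how cyclohexyl or a longer alkyl chain on the amine nitrogen would compare with cyclopentyl, and whether any group at this position can give a number lower than these aromatic compounds by more than the scatter.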